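Cytotoxicity notes on the oxime-bearing dihydropyran sulfone series

This account rests on a few compounds, and the source may have more. Where it says the series, first, only, none or still open, it means among the compounds named here.

Measured so far:
- compound 1, `CC1(Cc2cccc([N+](=O)[O-])c2)CC(S(=O)(=O)c2ccc(F)cc2)=C(c2ccc(/C(N)=N/O)cc2)O1`: 86600 nM
- compound 2, `CC1(Cc2ccc(-c3ccccc3)cc2F)CC(S(=O)(=O)c2ccc(F)cc2)=C(c2ccc(/C(N)=N/O)cc2)O1`: 24500 nM

In an ADME assay on cells (Peritoneal macrophage, Mus musculus, strain Balb/c) for cytotoxicity, read by resazurin assay, with a stated time of 72 h (on this read-out higher numbers stand for lower toxicity in this test and lower numbers for higher toxicity in this test), compound 1 gives 86600 nM, the highest number of the two measured, and so the least toxic of the pair on this read-out. Compound 2 gives 24500 nM in this assay; the gap between compound 1 and compound 2 lies beyond the scatter, so compound 2 is the more toxic of the two.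

Compound 3, `CC1(Cc2ccccc2Br)CC(S(=O)(=O)c2ccc(F)cc2)=C(c2ccc(/C(N)=N/O)cc2)O1`, is not yet measured. It differs from compound 1 in one place: 2-bromophenyl in place of 3-nitrophenyl on a saturated chain carbon bound to a saturated ring carbon. Among the measured compounds shown here, the shared core, the sulfone and the amidoxime-bearing aryl ring are kept; the only change is the group on the benzylic carbon.

For the measured compounds named here, no step of this exact kind is available among the measured compounds, so the expectation rests on the two numbers alone. The step from compound 1 to compound 3 is expected to be modest, toward a lower number, and possibly within the scatter: a 1.7-fold lower number from compound 1 to compound 3 (0.24 log units; within the scatter). Compound 3 is therefore expected to give about 50000 nM in this assay, with a plausible range from 20000 nM to 120000 nM.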

Compound 3, half-maximal cytotoxic concentration: 109000 nM
Compound 3: the middle estimate sits 2.2-fold (0.34 log units) below what was measured; low and high end bracket the measured number.
By their numbers in this assay, from the lowest: compound 2; then compounds 1 and 3 (each within the scatter of the next).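

In this assay, 2-bromophenyl in place of 3-nitrophenyl on a saturated chain carbon bound to a saturated ring carbon gives a 1.3-fold higher number from compound 1 to compound 3 (0.10 log units; within the scatter) for this pair, the first step read at this place in the series. Compound 1 and compound 3 therefore cannot be told apart on this read-out, even though the leaving group carries hydrogen-bond acceptors and the entering group carries none, and a bromine takes the place of the nitro group. No measurement at hand accounts for this result.

This single step changes both the substituent and where it stands on the phenyl ring, so it leaves open which of the two matters, or whether either does, at this place. Also open, from the compounds shown here alone, is whether a phenyl ring carrying an amine or a carboxylic acid, or a longer chain in place of the saturated chain carbon, would stay within the scatter of compound 1 or move the number beyond it.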